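The source may report more compounds than this note shows. Statements on the series, on what has been measured and on what is new or still open speak of the compounds shown alone.

Three compounds of the series have numbers in a functional assay on NCI-H226 cells (Homo sapiens) for inhibition, read by MTT assay, with a stated time of 48 h, tested at 10 uM; a higher number here means more inhibition at the concentration tested (going by the name of the read-out), a lower number less inhibition. Compound 1 `CCc1cccc(Nc2cc(NC(=O)Nc3cc(OC)cc(OC)c3)ncn2)c1` gives 36.7% in this assay. Compound 2 `COc1cc(Nc2cc(NC(=O)Nc3c(Cl)cccc3Cl)ncn2)cc(C(F)(F)F)c1` gives 33.1% in this assay, and compound 3 `CC(C)(C)c1cccc(Nc2cc(NC(=O)Nc3c(Cl)cccc3Cl)ncn2)c1` gives 36.5%. Compound 1 holds the highest of the three numbers, but its gaps to compound 3 and to compound 2 both lie within the usual scatter, so the three cannot be ranked against each other. Among the measured compounds shown here, no pair among the measured compounds differs in one place only, so no single structural step with a measured size is available from this set.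

Compound 4 `COc1cc(NC(=O)Nc2cc(Nc3ccc(F)c(Cl)c3)ncn2)cc(OC)c1` has not yet been measured. Against compound 1 the change is 3-chloro-4-fluorophenyl in place of 3-ethylphenyl on a nitrogen on an aromatic ring. The three measured compounds share the core of compound 1, differ in their substituents, and still return numbers within the scatter of one another, which gives no ground for expecting a move beyond the scatter in either direction. The expected step is therefore a number 1.7 percentage points lower from compound 1 to compound 4 (within the scatter). Compound 4 is estimated to give 35% in this assay, with a range from 20% to 50%.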

Compound 4, a percentage reported as inhibition, at one concentration (the size of the read-out at that concentration, not a potency): 36.7%
The estimate for compound 4 lay 1.7 percentage points below the measured number, within the range that was stated.
By their numbers in this assay, from the lowest: compounds 2, 3, 1 and 4 (each within the scatter of the next).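

The first step read at this position, 3-chloro-4-fluorophenyl in place of 3-ethylphenyl on a nitrogen on an aromatic ring, shows no change at the digits printed from compound 1 to compound 4 (within the scatter) in this assay and stays with the core of compound 1 unchanged. Among the compounds shown, a halogen-bearing phenyl and an alkyl-bearing phenyl with the same count of heavy atoms are therefore not told apart here, which the earlier compounds, none differing in one place only, could not show. Nothing available explains this absence of a step.

This rests on a single pair, read at one concentration, and says nothing about potency. On these data alone, whether a morpholine, a carboxylic acid or a longer alkyl chain on this phenyl ring would move the number beyond the scatter remains open.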